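This account rests on a few compounds, and the source may have more. Where it says the series, first, only, none or still open, it means among the compounds named here.

Measured compounds:
compound 1 `COc1cc(C(=O)NS(=O)(=O)c2ccccc2C)ccc1Cn1ncc2ccc(NC(=O)OC3CCCC3)cc21`, 10.2
compound 2 `COc1ccc(OC)c(S(=O)(=O)NC(=O)c2ccc(Cn3ccc4ccc(NC(=O)CC5CCCC5)cc43)c(OC)c2)c1`, 9.1
compound 3 `CCCCC(CC)C(=O)Nc1ccc2ccn(Cc3ccc(C(=O)NS(=O)(=O)c4ccccc4C)cc3OC)c2c1`, 8.9

In a functional assay (trachea) for antagonist activity, with Cavia porcellus as the target (a higher number here means a more potent compound, by a factor of ten per unit of this negative logarithm, a lower number a less potent compound), compound 3 gives the lowest of the three numbers. Its number stands close to that of compound 2, at a distance that is within the scatter of repeated measurements, so the two cannot be told apart. Compound 1 stands well above compound 3, beyond the scatter.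

Compound 4 `CCCCC(CC)C(=O)Nc1ccc2ccn(Cc3ccc(C(=O)NS(=O)(=O)c4ccccc4)cc3OC)c2c1` has not yet been measured. It differs from compound 3 in one place: hydrogen in place of methyl on an aromatic carbon. This is a small change on the ring that carries the sulfonyl group. Going by the values given here, no pair among the measured compounds shows this change, so no measured step can be borrowed for it. Given that the change removes only a methyl group, the step of a number 0.20 log units lower from compound 3 to compound 4 (within the scatter) is expected to be small, possibly a slight loss, and may well stay within the scatter. Compound 4 is therefore estimated at 8.7, with a range from 8 to 9.4.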

Compound 4, negative logarithm of the antagonist equilibrium constant: 8.6
Beside the measured number, compound 4's estimate is 0.10 log units above it, within the range that was stated.
By their numbers in this assay, from the lowest: compounds 4, 3 and 2 (each within the scatter of the next, the first and the last beyond it); then compound 1.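

In this assay, going from 2-methylphenyl to phenyl on the sulfonyl group gives a number 0.30 log units lower from compound 3 to compound 4 (within the scatter), so the two compounds cannot be told apart. Going by these compounds alone, this is the first pair in the set that differs in one place, and it shows that, on this core, the potency seen here does not depend on a methyl group at this position, ortho to a large group. No separate measurement bears on this result.

From the compounds shown here alone, whether an amine or a carboxylic acid on this aromatic carbon would leave the number unchanged remains open. Also open, going by these compounds, is whether the same change would be as small on the core of compound 1, which differs from compound 3 in more than one place.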